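A few compounds are considered here, and "the series" means these few. Any claim that something is new, unique, unknown or untested is made for them only; others in the source may bear on it.

Measured compounds:
Compound 1 `O=C(O)CCC(=O)/C=C/c1cn(-c2ccccc2)nc1-c1ccccc1`: 8.33%
Compound 2 `O=C(O)CCC(=O)/C=C/c1cn(-c2ccccc2)nc1-c1ccc(Cl)cc1`: 2.27%

In a functional assay on the whole organism (strain albino) for inhibition, with Rattus norvegicus as the target, read by paw edema, with stated times of 30 min and 24 h, at a dose of 50 mg/kg by the oral route (a lower number here means less inhibition, a higher number more inhibition at the dose given (going by the name of the read-out)), compound 1 gives 8.33% and compound 2 gives 2.27%. Among the compounds with values here, on these two numbers compound 2 stands at the lower of them, with compound 1 as its only neighbour, yet the step of a number 6.1 percentage points lower from compound 1 to compound 2 (within the scatter) lies within the scatter, so the pair cannot be told apart.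

Compound 3 `Cc1ccc(-c2nn(-c3ccccc3)cc2/C=C/C(=O)CCC(=O)O)cc1` is not yet measured. It differs from compound 2 as follows: methyl in place of chloro on an aromatic carbon. Within the data shown here, only one measured step bears on the same aromatic carbon, the one that put chloro in place of hydrogen, and it was a number 6.1 percentage points lower from compound 1 to compound 2 (within the scatter), within the scatter. Among the measured compounds shown here, no measured step exchanges chloro for methyl. The expected step is therefore a number 2.7 percentage points higher from compound 2 to compound 3 (within the scatter), nothing beyond the scatter. Compound 3 is expected to give about 5%, within a range from -5% to 15%.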

Compound 3, a percentage reported as inhibition, in the whole organism at one dose (the size of the read-out at that dose, not a potency): 3.79%
For compound 3 the middle estimate is 1.2 percentage points above the measured one; low and high end bracket the measured number.
By their numbers in this assay, from the lowest: compounds 2, 3 and 1 (each within the scatter of the next).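

In this assay, the exchange of chloro for methyl gives a number 1.5 percentage points higher from compound 2 to compound 3 (within the scatter), and methyl in place of hydrogen gives a number 4.5 percentage points lower from compound 1 to compound 3 (within the scatter). With one chloro step known before, this aromatic carbon, para to a large group, now carries hydrogen, chloro and methyl across compound 1, compound 2 and compound 3, and all three numbers lie within the scatter of their neighbours, so none of these changes at this position can be told from the others. No measurement here offers an explanation for this flat result.

Going by these compounds, it remains open whether a different group at this carbon, such as a methoxy group or an amine, would move the number beyond the scatter. On these data alone, it is equally open whether any change elsewhere on the shared core, such as an amide in place of the carboxylic acid, would do so.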